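The source may report more compounds than this note shows. Statements on the series, on what has been measured and on what is new or still open speak of the compounds shown alone.

Measured so far:
- compound 1, `COc1cc(Cc2nc3c(N)nc(F)nc3n2CCOC(C)C)cc(OC)c1OC`: 15800 nM
- compound 2, `CCC(CC)Cn1c(Cc2cc(OC)c(OC)c(OC)c2)nc2c(N)ncnc21`: 158000 nM

In a functional assay on MCF7 cells (Homo sapiens) for antiproliferative activity (on this read-out higher numbers stand for weaker inhibition and lower numbers for stronger inhibition), compound 1 gives the lower of the two numbers; compound 2 gives a number that stands beyond the scatter above it. Among the measured compounds shown here, no single-point step links these two, so only their two values are on record.

Compound 3, `CCCCCn1c(Cc2cc(OC)c(OC)c(OC)c2)nc2c(N)nc(F)nc21`, is not yet measured. It differs from compound 1 by propyl in place of isopropoxy on a saturated chain carbon, two bonds along the chain from an aromatic nitrogen. There is no measured step of this kind in the series, so the direction has to be taken from what the two values show: compound 2, which also carries a plain alkyl chain on the shared core, sits well above compound 1 in this assay.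

Compound 3 is therefore expected to come out somewhat weaker than compound 1, by a 1.9-fold higher number from compound 1 to compound 3 (0.28 log units; within the scatter), a step that may still sit within the scatter. The estimate for compound 3 in this assay is 30000 nM, with a range from 10000 nM to 100000 nM.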

Compound 3, half-maximal inhibitory concentration: 36300 nM
The estimate for compound 3 lay 1.2-fold (0.08 log units) below the measured number; low and high end bracket the measured number.
By their numbers in this assay, from the lowest: compound 1; then compound 3; then compound 2.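

In this assay, among the compounds shown here, replacing 2-isopropoxyethyl with pentyl on the shared core gives a 2.3-fold higher number from compound 1 to compound 3 (0.36 log units; beyond the scatter), the first direct reading at this position. The read-out therefore responds to this change, but only modestly, and the all-carbon pentyl chain stays on the weaker side of the isopropoxy-bearing chain. No measurement bears on why the number moves.

This single pair cannot separate the loss of the chain oxygen from the loss of branching at the chain end, since both change together. It also leaves open whether a terminal amine, a carboxylic acid or a longer chain at this position would move the number further in either direction, and whether the same step would hold on a core without the fluorine.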